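Swapping fluoro for hydrogen on compound 2

The compounds below may be only part of what the source reports. "The series", "measured", "known", "first", "only" and "open" are said of these compounds alone.

In a functional assay on QG-56 cells (Homo sapiens) for antiproliferative activity (a higher number here means a weaker inhibitor, a lower number a stronger inhibitor), compound 1 `Cn1cncc1C(O)(c1ccc(C(=O)OC(C)(C)C)cc1)c1cc2cc([N+](=O)[O-])cc(-c3ccccc3)c2o1` gives 6250 nM and compound 2 `Cn1cncc1C(O)(c1ccc(C#N)cc1)c1cc2cc([N+](=O)[O-])cc(-c3ccc(F)cc3)c2o1` gives 158 nM as the lower of the two numbers, a gap beyond the scatter. Among the measured compounds shown here, compound 3 `Cn1cncc1C(O)(c1ccc(C#N)cc1)c1cc2cc([N+](=O)[O-])cc(-c3ccccc3)c2o1` has hydrogen in place of fluoro on an aromatic carbon and no measured pair shows this change alone. A small step in this assay is expected, most likely none beyond the scatter, and if any, towards a higher number. The estimate means a 1.3-fold higher number from compound 2 to compound 3 (0.10 log units; within the scatter) as the expected step. For compound 3 the estimated value is 200 nM (70 nM to 600 nM).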

Compound 3, half-maximal inhibitory concentration: 1480 nM
Compound 3: middle estimate off by 7.4-fold (0.87 log units), on the low side; the whole stated range lies below it.
By their numbers in this assay, from the lowest: compound 2; then compound 3; then compound 1.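

In this assay the change from 4-fluorophenyl to phenyl is not a silent one (a 9.4-fold higher number from compound 2 to compound 3 (0.97 log units; beyond the scatter)), so fluoro at this place carries clear weight with the rest of compound 2 held fixed. With phenyl held fixed, the other aromatic substituent also counts (a 4.2-fold lower number from compound 1 to compound 3 (0.63 log units; beyond the scatter)), for cyano in place of tert-butoxycarbonyl. Nothing on hand explains either step. Still open, on these data alone, is whether chloro or methoxy at the fluoro place would match fluoro, and whether an amine or a carboxylic acid in place of cyano would shift the number further.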